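Swap at the five-membered ring: compound 2 to compound 3

A few compounds are considered here, and "the series" means these few. Any claim that something is new, unique, unknown or untested is made for them only; others in the source may bear on it.

Two compounds of this series carry results. Within the data shown here, compound 2 `Nc1nc(N2CCN(C(=O)COc3ccc(Cl)cc3)CC2)c2nc(CCCCc3ccc(F)cc3)sc2n1` is the reference point: in a functional assay on cells (Lymphocyte, Homo sapiens) (a lower number here means a stronger inhibitor, a higher number a weaker inhibitor), compound 2 gives 920 nM, the only full number in hand. Compound 1 `Nc1nc(N2CCN(S(=O)(=O)c3ccccc3)CC2)c2nc(-c3ccc(F)cc3)sc2n1` reaches only a limit of the assay, > 10000 nM in this assay (the limit of > 10000 nM in this assay, at which 1 of the 2 values shown sits). Compound 1 and compound 2 differ in more than one place, so their two values show only that one sits at the limit and the other gives a number, nothing more.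

Compound 3 `Nc1nc(N2CCN(C(=O)COc3ccc(Cl)cc3)CC2)c2nc(-c3cccnc3)sc2n1` is not yet measured. It keeps the amide side of compound 2 and changes the other substituent: pyridin-3-yl in place of 4-(4-fluorophenyl)butyl on an aromatic carbon. Nothing measured isolates this change, so the expected size of the step in this assay rests on compound 2 alone and on the limit seen for compound 1, which also carries a directly attached six-membered aromatic ring at that position. A loss beyond the scatter is expected. Compound 3 is expected to give about 3500 nM, within roughly 800 nM to 15000 nM. The step of a 3.8-fold higher number from compound 2 to compound 3 (0.58 log units; beyond the scatter) is the expected shift, with a real chance of a limit only.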

Compound 3, half-maximal inhibitory concentration: 50 nM
For compound 3 the middle estimate is 70-fold (1.85 log units) above the measured one, and the stated range ends above it.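

In this assay the substituent on the aromatic carbon next to the ring nitrogen and next to the ring sulfur has a large effect, with the amide side held constant: an 18-fold lower number from compound 2 to compound 3 (1.26 log units; beyond the scatter). The 4-(4-fluorophenyl)butyl group is therefore not required for a low number in this amide series, and a directly attached pyridin-3-yl is tolerated and gives the better result of the pair. Compound 1 also carries a directly attached six-membered aromatic ring at this position, but it differs from compound 3 in more than one place, so its limit cannot be assigned to that ring, and compound 3 shows that such a ring does not by itself put a compound at the limit: the limit of > 10000 nM in this assay, at which 1 of the 3 values shown sits.

The step combines the loss of the chain with the entry of the ring nitrogen, and the compounds shown do not separate these two changes. An unsubstituted phenyl ring attached directly at this carbon, or a butyl chain ending in pyridin-3-yl, would tell whether the ring nitrogen or the short attachment carries the step.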